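Para-substituent scan on the spirocyclic lactam core

The source may report more compounds than this note shows. Statements on the series, on what has been measured and on what is new or still open speak of the compounds shown alone.

Measured so far:
- Compound 1 `O=C1CCC2(c3ccc(F)cc3)OCCCN12`: in a functional assay on the whole organism (Central nervous system) for activation, with Mus musculus as the target (on this read-out higher numbers stand for an effect only at larger amounts of compound and lower numbers for an effect already at smaller amounts), compound 1 gives 75 mg/kg.
- Compound 2 `COc1ccc(C23CCC(=O)N2CCCO3)cc1`: compound 2 in this assay reaches only a limit, < 150 mg/kg, not a number.
- Compound 3 `O=C1CCC2(c3ccccc3)OCCCN12`: compound 3 in this assay gives 37.5 mg/kg.

Compound 3 holds the lowest of the two numbers; compound 1 sits nearest, and the step of a 2.0-fold lower number from compound 1 to compound 3 (0.30 log units; within the scatter) is within the scatter. The step that the limit leaves unreadable from compound 1 to compound 2 and the step that the limit leaves unreadable from compound 2 to compound 3 cannot be sized, as compound 2 shows only a limit (the limit of < 150 mg/kg in this assay, at which 1 of the 3 values shown sits).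

Compound 4 `O=C1CCC2(c3ccc(Cl)cc3)OCCCN12` differs from compound 3 by chloro in place of hydrogen on an aromatic carbon. Within the data shown here, the only readable step at this aromatic carbon is the one from compound 1 to compound 3, where a halogen leaving gave a shift within the scatter. Chloro entering at the same place is therefore expected to move this assay little, if at all, beyond the scatter; the estimated step is a 1.6-fold higher number from compound 3 to compound 4 (0.20 log units; within the scatter).

Compound 4 is expected to give about 60 mg/kg in this assay, within 30 mg/kg to 120 mg/kg.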

Compound 4, dose for half-maximal effect: 75 mg/kg
Compound 4: the middle estimate sits 1.3-fold (0.10 log units) below what was measured, and the stated range covers the measured number.
By their numbers in this assay, from the lowest: compounds 3, 1 and 4 (each within the scatter of the next).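

In this assay, a second halogen at this aromatic carbon, para to a large group, also stays within the scatter of the unsubstituted compound: a 2.0-fold higher number from compound 3 to compound 4 (0.30 log units; within the scatter). Chloro and fluoro are not told apart at this place: no change at the digits printed from compound 1 to compound 4 (within the scatter). Hydrogen, fluoro and chloro therefore give no readable separation here, while the steps involving the methoxy compound, compound 2, cannot be read: the limit of < 150 mg/kg in this assay, at which 1 of the 4 values shown sits.

From the compounds shown here alone, whether another kind of group at this aromatic carbon, such as an amine, a carboxylic acid or a nitrile, would move the number in this assay beyond the scatter remains open. Going by these compounds, the size of any methoxy shift also remains open, as does the outcome of a change to the shared core away from this aromatic carbon.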